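Series notes: thiourea side-chain changes and cytotoxicity on Ehrlich cells

The source may report more compounds than this note shows. Statements on the series, on what has been measured and on what is new or still open speak of the compounds shown alone.

Measured so far:
compound 1 `CCCCNC(=S)NC1=C(C#N)C(c2ccc(Cl)cc2Cl)C2=C(CCCC2=O)N1c1ccc(S(N)(=O)=O)cc1` — 30%
compound 2 `N#CC1=C(NC(=S)Nc2ccccc2)N(c2ccc(S(N)(=O)=O)cc2)C2=C(C(=O)CCC2)C1c1ccc(Cl)cc1Cl` — 50%
compound 3 `N#CC1=C(NC(N)=O)N(c2ccc(S(N)(=O)=O)cc2)C2=C(C(=O)CCC2)C1c1ccc(Cl)cc1Cl` — 35%

All three share one core and were tested in a functional assay on Ehrlich cells (Mus musculus) for cytotoxicity, read by trypan blue exclusion, with a stated time of 2 h, tested at 25 ug/mL; on this read-out lower numbers stand for a weaker effect and higher numbers for a stronger effect at the one concentration tested. Compound 1 gives the lowest of the three numbers; its nearest neighbour is compound 3, whose step a number 5 percentage points higher from compound 1 to compound 3 (within the scatter) stays within the scatter, while compound 2 stands furthest, with a number 20 percentage points higher from compound 1 to compound 2 (beyond the scatter). Between compound 2 and compound 3 the step is a number 15 percentage points lower from compound 2 to compound 3 (beyond the scatter).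

Compound 4 `N#CC1=C(NC(=O)CCC(=O)O)N(c2ccc(S(N)(=O)=O)cc2)C2=C(C(=O)CCC2)C1c1ccc(Cl)cc1Cl` is not yet measured. It differs from compound 1 in one place: a group of 7 heavy atoms (4 carbon, 3 oxygen; no ring) in place of a group of 7 heavy atoms (5 carbon, 1 nitrogen, 1 sulfur; no ring), on an amine nitrogen

Within the data shown here, only two measured steps change the group on this amine nitrogen. The phenyl-for-butyl step, a number 20 percentage points higher from compound 1 to compound 2 (beyond the scatter), is modest and upward; the step to the 3-heavy-atom group of compound 3, a number 5 percentage points higher from compound 1 to compound 3 (within the scatter), is within the scatter. Neither involves a (2-carboxyethyl)carbonyl group, so the bearing on compound 4 is loose. The step of a number 5 percentage points higher from compound 1 to compound 4 (within the scatter) is therefore expected to be small, without a clear direction beyond the scatter. For compound 4 a value of 35% is estimated, in the range 20% to 50%.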

Compound 4, a percentage reported as activity, at one concentration (the size of the read-out at that concentration, not a potency): 35%
Compound 4: the middle estimate sits on the measured number at the digits printed; the range from low to high includes it.
By their numbers in this assay, from the lowest: compounds 1, 3 and 4 (each within the scatter of the next); then compound 2.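

In this assay, 2-carboxyethyl in place of amino on the carbonyl carbon gives no change at the digits printed from compound 3 to compound 4 (within the scatter), and the (2-carboxyethyl)carbonyl group in place of the group of compound 1 gives a number 5 percentage points higher from compound 1 to compound 4 (within the scatter). Among these compounds, this amine nitrogen therefore carries three quite different groups with no separation beyond the scatter, and the new group is the first of them with neither sulfur nor a second nitrogen. Compound 2 remains apart, with a number 15 percentage points lower from compound 2 to compound 4 (beyond the scatter), and it is the only one of the four whose group holds an aromatic ring.

No supporting data bear on why these groups read alike or why compound 2 differs. The compounds shown leave open whether a benzyl group, a substituted phenyl or a longer chain ending in a carboxylic acid would separate from compound 2 or from compound 4 on this nitrogen.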